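Closing the Amino Group into a Ring

A few compounds are considered here, and "the series" means these few. Any claim that something is new, unique, unknown or untested is made for them only; others in the source may bear on it.

In an ADME assay on MT4 cells (Homo sapiens) for cytotoxicity, read by MTT assay, with a stated time of 4 days (a higher number here means that more compound is tolerated, a lower number that less compound is tolerated), compound 2 (`CC(C)N(C)c1nc(Cc2c(F)cccc2F)cc(=O)[nH]1`) gives 85000 nM. Compound 1 (`CCCNc1nc(C(C)c2c(F)cccc2F)c(C)c(=O)[nH]1`) gives 35000 nM. For the measured compounds named here, compound 2 thus has the higher of the two numbers so far, and the gap between them lies beyond the usual scatter. Compound 3 (`O=c1cc(Cc2c(F)cccc2F)nc(N2CCCC2)[nH]1`) carries pyrrolidin-1-yl in place of isopropyl(methyl)amino on an aromatic carbon. Going by the values given here, no measured pair shows what such a swap does, so this is a cautious judgment with a wide range. The expected change, a 1.3-fold lower number from compound 2 to compound 3 (0.12 log units; within the scatter), stays within the usual scatter. For compound 3, the estimated value is 65000 nM, with an expected range of 25000 nM to 140000 nM.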

Compound 3, half-maximal cytotoxic concentration: > 86000 nM
Compound 3: no number, only a limit (the forecaster's own chance of this, stated with the estimate: 20%); middle value at least 1.3-fold (0.12 log units) away from the limit.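

Closing isopropyl(methyl)amino into pyrrolidin-1-yl adds a ring without changing the count of heavy atoms, and in this assay compound 3 gives > 86000 nM, which is a limit and not a number. The step is an at least 1.0-fold higher number from compound 2 to compound 3 (0.00 log units; that floor lies within the scatter), so a ring at this position, on the aromatic carbon between two ring nitrogen atoms, brings no sign of lower tolerance. Its true size stays unknown: the limit of > 86000 nM in this assay, at which 1 of the 3 values shown sits.

From the compounds shown here alone, how larger rings such as piperidin-1-yl or morpholin-4-yl would fare at this position remains open.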